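Triazole-to-alkyne swap on a urea-linked series

This account rests on a few compounds, and the source may have more. Where it says the series, first, only, none or still open, it means among the compounds named here.

Compound 1 `C#CCNC(=O)CN(Cc1ccccc1)Cc1c(-c2ccc(NC(=O)NCC)cc2)nc2n(Cc3c(F)cccc3F)cc(C(=O)OCC)c(=O)n12`: 1000 nM
Compound 2 `CCNC(=O)Nc1ccc(-c2nc3n(Cc4c(F)cccc4F)cc(C(=O)OCC)c(=O)n3c2CN(CC(=O)NCc2cn(CCN=[N+]=[N-])nn2)Cc2ccccc2)cc1`: 724 nM
Compound 3 `CCOC(=O)c1cn(Cc2c(F)cccc2F)c2nc(-c3ccc(NC(=O)NCc4cn(CCN=[N+]=[N-])nn4)cc3)c(CN(C)Cc3ccccc3)n2c1=O`: 2570 nM

In a functional assay on CHO cells for antagonist activity at Gonadotropin-releasing hormone receptor (Homo sapiens), read by a luciferase reporter, with a stated time of 30 min (a lower number here means a stronger inhibitor, a higher number a weaker inhibitor), compound 2 gives 724 nM and compound 1 gives 1000 nM; the change ethynyl in place of 1-(2-azidoethyl)-1H-1,2,3-triazol-4-yl on a saturated chain carbon bound to an amide-type nitrogen made a step of a 1.4-fold higher number from compound 2 to compound 1 (0.14 log units; within the scatter). Compound 3 shows 2570 nM, the highest of the three; the difference between the core of compound 3 and the core of compound 2 is not broken down here. Compound 4 `C#CCNC(=O)Nc1ccc(-c2nc3n(Cc4c(F)cccc4F)cc(C(=O)OCC)c(=O)n3c2CN(C)Cc2ccccc2)cc1` carries the same change, (ethynyl in place of 1-(2-azidoethyl)-1H-1,2,3-triazol-4-yl on a saturated chain carbon bound to an amide-type nitrogen), at the same place. Since the earlier step was a 1.4-fold higher number from compound 2 to compound 1 (0.14 log units; within the scatter), the step from compound 3 to compound 4 is expected to be similar, a 1.2-fold higher number from compound 3 to compound 4 (0.07 log units; within the scatter). Compound 4 is therefore estimated at 3000 nM, between 1500 nM and 6000 nM.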

Compound 4, half-maximal inhibitory concentration: 676 nM
Estimate against measurement, compound 4: 4.4-fold (0.65 log units) above, outside the stated range (below it).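

In this assay, putting ethynyl in place of 1-(2-azidoethyl)-1H-1,2,3-triazol-4-yl gave a 3.8-fold lower number from compound 3 to compound 4 (0.58 log units; beyond the scatter), so the change did not carry over as a constant step from one core to the other: the same change on two cores in this assay, a 1.4-fold higher number (0.14 log units; within the scatter) from compound 2 to compound 1 and a 3.8-fold lower number (0.58 log units; beyond the scatter) from compound 3 to compound 4, 5.3-fold (0.72 log units) apart, beyond the scatter of two such steps

The size of this step therefore depends on the core it is made on, and an earlier step on one core is a poor guide to the same change on another. Among these compounds, with only two pairs, this does not show which feature of the cores sets the difference, nor how the change would behave on any third core.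

The compounds shown leave open whether other cores would follow the pair of compound 2 and compound 1 or the pair of compound 3 and compound 4. They also leave open how a longer chain ending in an amine or a carboxylic acid would fare at the same place.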